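A few compounds are considered here, and "the series" means these few. Any claim that something is new, unique, unknown or untested is made for them only; others in the source may bear on it.

Measured compounds:
compound 1 `CC[C@H](C)[C@H](N)CN(C(=O)[C@@H]1C[C@H]1c1cccc(OC)c1)c1ccc(-c2ccccc2)cc1` gives 3000 nM in a functional assay for agonist activity at G protein-coupled receptor 88 (Homo sapiens), read by HTRF and cAMP accumulation; a higher number here means that more compound is needed for the effect, a lower number that less compound is needed
compound 2 `CC[C@H](C)[C@H](N)CN(C(=O)[C@@H]1C[C@H]1c1cccc(C)c1)c1ccc(-c2ccccc2)cc1` gives 1200 nM in this assay
compound 3 `CC[C@H](C)[C@H](N)CN(C(=O)[C@@H]1C[C@H]1c1ccc(F)c(F)c1)c1ccc(-c2ccccc2)cc1` gives 720 nM in this assay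

Compound 3 holds the lowest number of the three. Its gap to compound 2 lies within the scatter, so no order between these two is claimed; its gap to compound 1 lies beyond the scatter.

Compound 4 `CC[C@H](C)[C@H](N)CN(C(=O)[C@@H]1C[C@H]1c1ccncc1)c1ccc(-c2ccccc2)cc1` is the next point. It differs from compound 3 by pyridin-4-yl in place of 3,4-difluorophenyl on a saturated ring carbon. All three measured steps change the aromatic group on that same saturated ring carbon: a 2.5-fold lower number from compound 1 to compound 2 (0.40 log units; beyond the scatter), a 4.2-fold lower number from compound 1 to compound 3 (0.62 log units; beyond the scatter), and a 1.7-fold lower number from compound 2 to compound 3 (0.22 log units; within the scatter). Among the compounds with values here, every step so far has been modest, and the group entering in compound 4 is the first that brings a hetero atom into the aromatic ring and a hydrogen-bond acceptor, so none of the measured steps covers this change directly. On the evidence of modest steps for the earlier swaps, a modest step is expected here too; without a precedent for the heteroaromatic ring, a rise in the number is taken as somewhat more likely than a fall, but the range is kept wide.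

Compound 4 is therefore estimated at 2500 nM in this assay, with a range from 700 nM to 9000 nM. This estimate means an expected step of a 3.5-fold higher number from compound 3 to compound 4 (0.54 log units; beyond the scatter).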

Compound 4, half-maximal effective concentration: 1500 nM
Compound 4: middle estimate off by 1.7-fold (0.22 log units), on the high side; low and high end bracket the measured number.
By their numbers in this assay, from the lowest: compounds 3, 2, 4 and 1 (each within the scatter of the next, the first and the last beyond it).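

In this assay, pyridin-4-yl on the saturated ring carbon of the three-membered ring brings the first hetero atom and the first hydrogen-bond acceptor into the aromatic group at this position, and this gives a 2.1-fold higher number from compound 3 to compound 4 (0.32 log units; beyond the scatter) as a modest step. The same position read against the two other carbon-only aromatic groups gives a 1.3-fold higher number from compound 2 to compound 4 (0.10 log units; within the scatter) and a 2.0-fold lower number from compound 1 to compound 4 (0.30 log units; within the scatter) so that, among the aromatic groups shown, only the change from 3,4-difluorophenyl separates from pyridin-4-yl by more than the scatter, and a ring nitrogen at this carbon is compatible with a number in the same range as 3-methylphenyl and 3-methoxyphenyl. No measurement on hand gives a reason for the size of any of these steps.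

The compounds shown leave open whether the step from compound 3 to compound 4 follows from the ring nitrogen or from the loss of the two fluorines, a question that a fluoropyridine or a 4-fluorophenyl group on the same carbon would address. Also open, from the compounds shown here alone, is how this position responds to a pyrimidine ring, a pyridin-3-yl group, or a phenyl ring carrying an amine or a carboxylic acid.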